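One More Methoxy on Compound 3: What to Expect

A few compounds are considered here, and "the series" means these few. Any claim that something is new, unique, unknown or untested is made for them only; others in the source may bear on it.

Of the compounds shown here, three sharing one core have been measured in an ADME assay on NHDF cells (Homo sapiens) for cytotoxicity, read by MTT assay, with a stated time of 72 h; on this read-out lower numbers stand for stronger inhibition and higher numbers for weaker inhibition. Compound 1 (`COc1cccc(/C=C2\CCC/C(=C\c3cccc(OC)c3OC)C2=O)c1`) gives 16400 nM, compound 2 (`COc1ccc(/C=C2\CCC/C(=C\c3cccc(OC)c3OC)C2=O)cc1`) gives 43500 nM, and compound 3 (`COc1ccc(/C=C2\CCC/C(=C\c3cccc(OC)c3OC)C2=O)cc1OC`) gives 14900 nM. Compound 3 therefore sits level with compound 1 within the scatter, and both stand below compound 2.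

Compound 4 (`COc1cccc(/C=C2\CCC/C(=C\c3cc(OC)c(OC)c(OC)c3)C2=O)c1OC`) differs from compound 3 by one change, methoxy in place of hydrogen on an aromatic carbon. The new group lies ortho to a methoxy group, meta to a large group and meta to a methoxy group.

Two measured steps made the same kind of swap. The step of a 1.1-fold lower number from compound 1 to compound 3 (0.04 log units; within the scatter) shows no real change, whereas the step of a 2.9-fold lower number from compound 2 to compound 3 (0.47 log units; beyond the scatter) is modest. Both lead to compound 3, yet they differ in size, so this swap has no single measured effect. Neither step tests the exact carbon that changes in compound 4. The flat step and the modest step both point, at most, towards a slightly lower number, so only a small move is expected. The expected change is a 1.1-fold lower number from compound 3 to compound 4 (0.06 log units; within the scatter), which would not stand clear of the scatter. For compound 4 the estimated value is 13000 nM, with an expected range from 5500 nM to 32000 nM.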

Compound 4, half-maximal inhibitory concentration: 7900 nM
Estimate against measurement, compound 4: 1.6-fold (0.22 log units) above, within the range that was stated.
By their numbers in this assay, from the lowest: compounds 4, 3 and 1 (each within the scatter of the next, the first and the last beyond it); then compound 2.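

Among these compounds, the new methoxy sits ortho to a methoxy group, meta to a large group and meta to a methoxy group, and it gives a 1.9-fold lower number from compound 3 to compound 4 (0.28 log units; within the scatter) in this assay and so shows that this carbon, which no earlier step tested, takes the group without a shift that stands clear of the scatter. Three swaps of hydrogen for methoxy can now be compared, none of them raises the number, and only a 2.9-fold lower number from compound 2 to compound 3 (0.47 log units; beyond the scatter) lies beyond the scatter, so among the steps shown the flat result is the more common one for this change. Nothing measured here explains these numbers, so the reason for the small step stays unknown.

Still open, on these data alone, is whether this result belongs to methoxy itself or would also hold for a different group on the same carbon, such as a hydroxyl group, a fluorine atom or a longer chain like ethoxy. An amine or a carboxylic acid at this place would be a sharper test, since either would show how far the tolerance seen with methoxy extends.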